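A few compounds are considered here, and "the series" means these few. Any claim that something is new, unique, unknown or untested is made for them only; others in the source may bear on it.

Compound 1 `COc1ncnc2c1c(-c1ccsc1)cn2[C@@H]1O[C@H](CO)[C@@H](O)[C@H]1O` gives 5170 nM in a functional assay on A549 cells (Homo sapiens), read by MTT assay, with a stated time of 72 h; a lower number here means a stronger inhibitor, a higher number a weaker inhibitor. Compound 2 `CN(C)c1ncnc2c1c(-c1ccsc1)cn2[C@@H]1O[C@H](CO)[C@@H](O)[C@H]1O` gives only a limit of the assay in this assay, namely > 20000 nM.

Within the data shown here, of the two measured compounds, compound 2 is thus the one for which no number is known, only a limit; it sits at the limit of > 20000 nM in this assay, at which 1 of the 2 values shown sits. Among the measured compounds shown here, the single step between the measured compounds is an at least 3.8-fold higher number from compound 1 to compound 2 (0.58 log units; beyond the scatter), a change of dimethylamino in place of methoxy on an aromatic carbon. Compound 3 `C#Cc1cn([C@@H]2O[C@H](CO)[C@@H](O)[C@H]2O)c2ncnc(N(C)C)c12` keeps the dimethylamino of compound 2 and differs from it elsewhere: ethynyl in place of thiophen-3-yl on an aromatic carbon. No measured step concerns thiophen-3-yl or ethynyl, so the only step shown, an at least 3.8-fold higher number from compound 1 to compound 2 (0.58 log units; beyond the scatter), bears on the change from compound 2 to compound 3 merely by fixing the starting point at a limit; it gives no direction for the new change. The expectation is therefore wide and centred where compound 2 stands. Compound 3 is estimated at 20000 nM, with a range from 5000 nM to 60000 nM. This estimate amounts to an expected a number no higher from compound 2 to compound 3 (the limit leaves the size open), which is no step beyond the scatter.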

Compound 3, half-maximal inhibitory concentration: 390 nM
The estimate for compound 3 lay 51-fold (1.71 log units) above the measured number; measured number below the stated range.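

The aromatic carbon that carries thiophen-3-yl or ethynyl turns out to matter a great deal in this assay: the change to ethynyl gives an at least 51-fold lower number from compound 2 to compound 3 (1.70 log units; beyond the scatter). Until now, the only change shown was the one from methoxy to dimethylamino on the shared core, and it went towards weaker inhibition. Compound 3 keeps dimethylamino and gives 390 nM, so that group alone does not keep a compound from giving a measured number. The step can be read in its direction but not in its full size, since compound 2 has no number, only a limit: the limit of > 20000 nM in this assay, at which 1 of the 3 values shown sits.

The compounds shown do not tell what it is about ethynyl that counts, whether the absence of a ring or the triple bond itself, and a nitrile or a longer propynyl chain on the same carbon would help to separate the two. From the compounds shown here alone, it also stays open whether ethynyl gives a step of similar size when methoxy stands in place of dimethylamino, or when a plain amine stands there.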